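Ester variation on the shared core in Vero cytotoxicity

The source may hold more compounds than are shown below. What is called first, only, known or untested is meant among the compounds shown, and "the series" means these compounds.

Compound 1 `Cc1cccc(C(=O)OC2CCC(CN3CCN(c4cc(=O)c5cc(C(F)(F)F)cc([N+](=O)[O-])c5s4)CC3)CC2)c1` carries a 3-methylphenyl group on the ester carbonyl carbon. In an ADME assay on Vero cells (Chlorocebus sabaeus) for cytotoxicity, read by MTT assay, with a stated time of 48 h (a higher number here means a weaker inhibitor, a lower number a stronger inhibitor), compound 1 returns only a limit, > 64 ug/mL. Compound 2 `O=C(OC1CCC(CN2CCN(c3cc(=O)c4cc(C(F)(F)F)cc([N+](=O)[O-])c4s3)CC2)CC1)C1CCC1` has cyclobutyl in that place. In this assay compound 2 likewise stops at a limit, > 64 ug/mL. Compound 3 `O=C(OC1CCC(CN2CCN(c3cc(=O)c4cc(C(F)(F)F)cc([N+](=O)[O-])c4s3)CC2)CC1)c1ccc(F)cc1` has 4-fluorophenyl there. In this assay compound 3 also gives a limit, > 64 ug/mL. The steps a step that the two limits leave unreadable from compound 1 to compound 2, a step that the two limits leave unreadable from compound 1 to compound 3 and a step that the two limits leave unreadable from compound 2 to compound 3 therefore cannot be sized, and compound 1 cannot be placed relative to the other two because of the limit of > 64 ug/mL in this assay, at which 3 of the 3 values shown sit.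

Compound 4 `COc1ccc(C(=O)OC2CCC(CN3CCN(c4cc(=O)c5cc(C(F)(F)F)cc([N+](=O)[O-])c5s4)CC3)CC2)cc1` is the next member. 4-methoxyphenyl in place of 3-methylphenyl on a carbonyl carbon Both measured steps leaving compound 1 alter the same carbonyl substituent and both remain unreadable, so no direction is indicated. Going by the values given here, with every value so far at the same limit, the step expected in this assay is a step that the limit leaves unreadable from compound 1 to compound 4, nothing beyond the scatter. Compound 4 is estimated at 80 ug/mL, within 40 ug/mL to 200 ug/mL, and most likely as a limit again.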

Compound 4, half-maximal inhibitory concentration: > 64 ug/mL
Compound 4: a limit, no number (the forecaster's own chance of this, stated with the estimate: 85%); the middle value is on the limit's open side.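

No step from compound 4 to compound 1, compound 2 or compound 3 can be read, because each of these compounds returns only a limit: the limit of > 64 ug/mL in this assay, at which 4 of the 4 values shown sit. The compounds shown leave open how these four ester groups rank in this assay.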